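Half-life notes on the step from compound 2

The source may report more compounds than this note shows. Statements on the series, on what has been measured and on what is new or still open speak of the compounds shown alone.

Measured so far in an ADME assay on microsomes from liver (Homo sapiens) for metabolic stability; on this read-out higher numbers stand for a longer-lived compound and lower numbers for a shorter-lived compound
- compound 1 `COc1cc(OCc2cccc(-c3cnc(OC)nc3)c2)c2cc(-c3cn4nc(OC)sc4n3)oc2c1` gives 0.6 h
- compound 2 `COc1cc(OCc2cccc(-c3cncnc3)c2)c2cc(-c3cn4nc(OC)sc4n3)oc2c1` gives 0.117 h

Compound 2 holds the lower of the two numbers in this assay and is the reference here. Compound 3 `COc1cc(OCc2cccc(OCc3ccccc3)c2)c2cc(-c3cn4nc(OC)sc4n3)oc2c1` follows from compound 2 through benzyloxy in place of pyrimidin-5-yl on an aromatic carbon and keeps the shared core. Going by the values given here, only one measured step bears on this, a 5.1-fold lower number from compound 1 to compound 2 (0.71 log units; beyond the scatter) (hydrogen in place of methoxy on an aromatic carbon), which was modest and beyond the scatter. Among the compounds with values here, it shows how far the number can move, but it does not test benzyloxy, and no measured compound carries that group. Compound 2 at 0.117 h is the lowest number seen so far, so a small rise that stays within the scatter is expected. The estimated step is a 1.7-fold higher number from compound 2 to compound 3 (0.23 log units; within the scatter) and remains uncertain. Compound 3 is expected at 0.2 h with an estimated range from 0.07 h to 0.6 h as the working estimate.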

Compound 3, half-life: 1.43 h
Compound 3: middle estimate off by 7.2-fold (0.85 log units), on the low side; the whole stated range lies below it.
By their numbers in this assay, from the lowest: compound 2; then compound 1; then compound 3.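

In this assay, the group at this position, on an aromatic carbon of a six-membered aromatic ring of carbon only and meta to a large group, can carry a large change: benzyloxy in place of pyrimidin-5-yl gives a 12-fold higher number from compound 2 to compound 3 (1.09 log units; beyond the scatter), a wider range than the earlier compounds had shown. Benzyloxy in place of 2-methoxypyrimidin-5-yl gives a 2.4-fold higher number from compound 1 to compound 3 (0.38 log units; beyond the scatter), so in this set a methoxy-bearing pyrimidine is not required for the longer half-life, and compound 3 stands beyond the scatter from both others. Nothing available explains the rise.

Open, from the compounds shown here alone, is how much of the change belongs to the oxygen and methylene link and how much to the carbon-only ring, a question a directly attached phenyl would address. Also open, going by these compounds, is how an amine or a carboxylic acid at this position would read in this assay.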